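This account rests on a few compounds, and the source may have more. Where it says the series, first, only, none or still open, it means among the compounds named here.

Of the compounds shown here, three with a shared core have so far been tested in an ADME assay on the whole organism (Rattus norvegicus, strain Sprague-Dawley) for pharmacokinetics, read by LC-MS, at a dose of 1 mg/kg by the intravenous route; on this read-out lower numbers stand for slow clearance and higher numbers for fast clearance. Compound 1 `Cc1cccc(Cl)c1CN1CCc2cc(-c3c(C)nc(C)c([C@H](OC(C)(C)C)C(=O)O)c3N3CCC(C)(C)CC3)ccc2C1` gives 3.5 mL/min/kg, compound 2 `Cc1cccc(F)c1CN1CCc2cc(-c3c(C)nc(C)c([C@H](OC(C)(C)C)C(=O)O)c3N3CCC(C)(C)CC3)ccc2C1` gives 5.8 mL/min/kg and compound 3 `Cc1nc(C)c([C@H](OC(C)(C)C)C(=O)O)c(N2CCC(C)(C)CC2)c1-c1ccc2c(c1)CCN(Cc1cccc(F)c1F)C2` gives 8.1 mL/min/kg. Compound 3 is the starting point here. Its nearest neighbour is close, with a gap of a 1.4-fold higher number from compound 2 to compound 3 (0.15 log units; within the scatter), and its furthest neighbour is only modestly removed, at a 2.3-fold higher number from compound 1 to compound 3 (0.36 log units; beyond the scatter).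

Compound 4 `Cc1nc(C)c([C@H](OC(C)(C)C)C(=O)O)c(N2CCC(C)(C)CC2)c1-c1ccc2c(c1)CCN(Cc1ccc(F)cc1F)C2` has not yet been measured. It has the same atoms as compound 3, joined differently: 2,4-difluorophenyl in place of 2,3-difluorophenyl on a saturated chain carbon bound to an amine nitrogen in a ring. In words, this is 2,4-difluorophenyl in place of 2,3-difluorophenyl on a saturated chain carbon bound to an amine nitrogen in a ring.

Among the measured compounds shown here, no measured step moves a fluorine around the ring in this way, so the evidence is indirect. The closest guides are the other changes to this same aromatic group. Two of them stay within the scatter, a 1.7-fold higher number from compound 1 to compound 2 (0.22 log units; within the scatter) and a 1.4-fold higher number from compound 2 to compound 3 (0.15 log units; within the scatter), and only the largest swap, a 2.3-fold higher number from compound 1 to compound 3 (0.36 log units; beyond the scatter), goes beyond it. On that basis, no step beyond the scatter is expected in this assay.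

The expected step is a 1.0-fold lower number from compound 3 to compound 4 (0.01 log units; within the scatter). Compound 4 is estimated at 8 mL/min/kg, with an expected range of 4.5 mL/min/kg to 14 mL/min/kg.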

Compound 4, clearance: 20.1 mL/min/kg
Beside the measured number, compound 4's estimate is 2.5-fold (0.40 log units) below it, and the stated range ends below it.
By their numbers in this assay, from the lowest: compounds 1, 2 and 3 (each within the scatter of the next, the first and the last beyond it); then compound 4.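

Moving one fluorine, so that 2,4-difluorophenyl replaces 2,3-difluorophenyl on the same saturated chain carbon, leaves the counted atoms unchanged, yet in this assay it gives a 2.5-fold higher number from compound 3 to compound 4 (0.39 log units; beyond the scatter) and so shows that the arrangement of the fluorines on this ring can matter, not just which atoms the ring carries. The two wider swaps reach further, with a 3.5-fold higher number from compound 2 to compound 4 (0.54 log units; beyond the scatter) and a 5.7-fold higher number from compound 1 to compound 4 (0.76 log units; beyond the scatter), which puts compound 4 beyond the scatter of all three earlier compounds and gives it the fastest clearance of the four. Nothing available here accounts for this difference in clearance.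

The compounds shown leave open whether the higher number follows from the 2,4-difluorophenyl arrangement in general or from fluorine in particular, a question that a 2,4-dichlorophenyl or 2,4-dimethylphenyl group in the same place would address. Among the compounds shown here, it also remains open how an unsubstituted phenyl group would compare, and whether the step from 2,3-difluorobenzyl to 2,4-difluorobenzyl would be of similar size on a different core, as this single pair offers only one example.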